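The source may report more compounds than this note shows. Statements on the series, on what has been measured and on what is new or still open speak of the compounds shown alone.

The study concerns compound 1 `COc1ccc(NC(=O)NC2CC(C)(C)Oc3ccc(Cl)cc32)cc1`, compound 2 `COc1ccc(NC(=O)NC2CC(C)(C)Oc3ccc(Br)cc32)cc1`, compound 3 `Cc1cccc(NC(=O)NC2CC(C)(C)Oc3ccc(Cl)cc32)c1` and compound 4 `Cc1cccc(NC(=O)NC2CC(C)(C)Oc3ccc(Br)cc32)c1`, all tested in a functional assay (aorta) with Rattus norvegicus as the target; a higher number here means that more compound is needed for the effect, a lower number that less compound is needed. Compound 1 gives > 30000 nM, which is a limit of the assay. Compound 2 gives > 10000 nM, likewise a limit. Compound 3 gives > 10000 nM, again a limit. Hence a step that the two limits leave unreadable from compound 1 to compound 2, the change being (bromo in place of chloro on an aromatic carbon). The cores of compound 1 and compound 3 differ by 3-methylphenyl in place of 4-methoxyphenyl on an amide-type nitrogen, and a step that the two limits leave unreadable from compound 1 to compound 3. The change from compound 3 to compound 4 is the same change, (bromo in place of chloro on an aromatic carbon). Because the limit of > 10000 nM in this assay, at which 2 of the 3 values shown sit, and the limit of > 30000 nM in this assay, at which 1 of the 3 values shown sits, are all that the three values show, the step from compound 3 to compound 4 is expected to be a step that the limit leaves unreadable from compound 3 to compound 4. For compound 4 the expected value in this assay is 30000 nM.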

Compound 4, half-maximal effective concentration: > 10000 nM
Compound 4: a limit, no number; the forecaster's own chance of this, stated with the estimate: 85%; the middle value does not contradict the limit.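

Compound 4 gives only a limit, and neither the step from compound 3 to compound 4 nor the step from compound 2 to compound 4 can be read. The compounds shown leave open whether either change alters the result in this assay at all: all four values are limits.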